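Tryptamine-piperidine series: swapping the ring-carbon amine substituent

The source may report more compounds than this note shows. Statements on the series, on what has been measured and on what is new or still open speak of the compounds shown alone.

Measured so far:
- Compound 1, `CN(Cc1ccc(S(C)(=O)=O)cc1)C1CCN(CCCc2c[nH]c3ccc(-n4cnnc4)cc23)CC1`; in an assay on CHO cells for displacement of a labelled ligand from 5-hydroxytryptamine receptor 1B (Homo sapiens) (a higher number here means a weaker inhibitor, a lower number a stronger inhibitor), compound 1 gives 140 nM.
- Compound 2, `C[C@H](NCC1CCN(CCCc2c[nH]c3ccc(-n4cnnc4)cc23)CC1)c1ccccc1`; in this assay compound 2 gives 58 nM.

Compound 2 holds the lower of the two numbers in this assay, and its gap to compound 1 lies beyond the usual scatter of this kind of measurement. Both share the same core; they differ only in what hangs from the saturated ring carbon.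

The next compound, compound 3, `CC(C)=CCN(C)C1CCN(CCCc2c[nH]c3ccc(-n4cnnc4)cc23)CC1`, has not yet been measured in this assay. Relative to compound 2 it carries methyl(3-methylbut-2-en-1-yl)amino in place of ((1-phenylethyl)amino)methyl on a saturated ring carbon. The aromatic ring and the hydrogen-bond donor are gone, and the nitrogen now sits directly on the ring carbon, as it does in compound 1, with a short branched alkenyl chain in place of the aryl-bearing arm.

For the measured compounds named here, no measured pair isolates this change. Going by the values given here, the expectation, resting on compound 1 with its 140 nM as the only other tertiary-amine example, is a step toward weaker binding from compound 2 to compound 3 of about a 2.6-fold higher number from compound 2 to compound 3 (0.41 log units; beyond the scatter). For compound 3 the estimate in this assay is 150 nM, with a plausible range of 50 nM to 450 nM.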

Compound 3, half-maximal inhibitory concentration: 41 nM
Beside the measured number, compound 3's estimate is 3.7-fold (0.56 log units) above it; measured number outside the range, below it.
By their numbers in this assay, from the lowest: compounds 3 and 2 (each within the scatter of the next); then compound 1.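

In this assay, replacing ((1-phenylethyl)amino)methyl with methyl(3-methylbut-2-en-1-yl)amino on this saturated ring carbon gives a 1.4-fold lower number from compound 2 to compound 3 (0.15 log units; within the scatter), so the two compounds cannot be told apart even though the six-membered aromatic ring, the hydrogen-bond donor and the defined stereocentre all leave with the old group. Among the amines held directly on the ring carbon, 2-methylprop-1-en-1-yl in place of 4-(methylsulfonyl)phenyl gives a 3.4-fold lower number from compound 1 to compound 3 (0.53 log units; beyond the scatter), which shows that an aryl group on the amine arm is not needed for binding in this range and that the end of this arm can move the number beyond the scatter. No measurement offered here explains either step.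

The compounds shown do not separate the contribution of the methylsulfonyl group in compound 1 from that of its phenyl ring, and a plain benzyl group on the same amine nitrogen would address this. They also leave open whether the double bond of the 3-methylbut-2-en-1-yl chain matters, a question for the saturated 3-methylbutyl chain.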